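Ethoxy for Propynyl on the Thiophene Side Chain

The source may hold more compounds than are shown below. What is called first, only, known or untested is meant among the compounds shown, and "the series" means these compounds.

Compound 3 (`CC#CC(CC(=O)O)c1ccc(OCc2cccc(-c3c(C)cccc3C)c2)s1`) gives 210 nM in a functional assay on cells for agonist activity at Free fatty acid receptor 1 (Homo sapiens), read by calcium flux (on this read-out higher numbers stand for an effect only at larger amounts of compound and lower numbers for an effect already at smaller amounts), and has the highest number of the three compounds measured. Compound 1 (`Cc1cccc(C)c1-c1cccc(COc2ccc(CCC(=O)O)s2)c1`) gives 32 nM and compound 2 (`Cc1cccc(C)c1-c1cccc(COc2ccc(CC3SC(=O)NC3=O)s2)c1`) gives 82 nM. The change from compound 3 to compound 4 (`CCO[C@@H](CC(=O)O)c1ccc(OCc2cccc(-c3c(C)cccc3C)c2)s1`) is 2-carboxy-1-ethoxyethyl in place of 1-(carboxymethyl)but-2-yn-1-yl on an aromatic carbon; the carboxymethyl-bearing chain carbon keeps a substituent, but an ethoxy replaces the prop-1-yn-1-yl.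

The step that bears most directly on this is a 6.6-fold higher number from compound 1 to compound 3 (0.82 log units; beyond the scatter), where adding the prop-1-yn-1-yl to that chain carbon raised the number. Compound 4 again carries a group on that carbon, so its number is expected to sit between compound 1 and compound 3, and closer to compound 3. The step of a 2.6-fold higher number from compound 2 to compound 3 (0.41 log units; beyond the scatter) also ends at compound 3 but concerns a different exchange and gives no direct guide. Among the compounds with values here, on balance a modest fall in the number is expected, a 1.8-fold lower number from compound 3 to compound 4 (0.24 log units; within the scatter), since the only measured step onto that chain carbon was a 6.6-fold higher number from compound 1 to compound 3 (0.82 log units; beyond the scatter) and the new group is smaller. Compound 4 is therefore estimated at 120 nM, with a range from 40 nM to 400 nM.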

Compound 4, half-maximal effective concentration: 40100 nM
Compound 4: the middle estimate sits 330-fold (2.52 log units) below what was measured, outside the stated range (above it).
By their numbers in this assay, from the lowest: compound 1; then compound 2; then compound 3; then compound 4.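

In this assay, exchanging the prop-1-yn-1-yl for ethoxy on the chain carbon gives a 190-fold higher number from compound 3 to compound 4 (2.28 log units; beyond the scatter), a far larger move than any earlier step, although the side chains that leave and enter match in heavy-atom count. Ethoxy in place of hydrogen on that carbon gives a 1300-fold higher number from compound 1 to compound 4 (3.10 log units; beyond the scatter), against a 6.6-fold higher number from compound 1 to compound 3 (0.82 log units; beyond the scatter) for the prop-1-yn-1-yl, and the exchange of the (2,4-dioxo-1,3-thiazolidin-5-yl)methyl side chain for 2-carboxy-1-ethoxyethyl gives a 490-fold higher number from compound 2 to compound 4 (2.69 log units; beyond the scatter), so at this position the identity of the group matters far more than the mere presence of a substituent. Nothing available accounts for the size of this jump.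

From the compounds shown here alone, compound 4 carries one defined stereocentre, and it remains open whether the opposite configuration at that carbon would give a similar number or whether the configuration contributes to the jump at all. Going by these compounds, it is also open whether a methoxy, a hydroxy or a propyl group on the same carbon would stay near compound 3 or follow compound 4, which would show whether the ether oxygen or the chain length tracks with the change.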